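The source may report more compounds than this note shows. Statements on the series, on what has been measured and on what is new or still open speak of the compounds shown alone.

Working notes on the series. Three compounds have numbers in an assay on microsomes from liver for inhibition of acyl-CoA desaturase 1 (Rattus norvegicus); on this read-out higher numbers stand for weaker inhibition and lower numbers for stronger inhibition. Compound 1 `FC(F)(F)c1ccc(OC2CCN(c3ccc(-n4ccnc4)nn3)CC2)cc1` gives 371 nM. Compound 2 `FC(F)(F)c1ccccc1OC1CCN(c2ccc(-c3nnco3)nn2)CC1` gives 22 nM. Compound 3 `CCc1ccccc1OC1CCN(c2ccc(-n3ccnc3)nn2)CC1` gives 4 nM, the lowest of the three numbers; compound 2, its nearest neighbour, sits beyond the scatter above it, and compound 1, the furthest, sits well beyond the scatter above it. Compound 3 is thus the strongest inhibitor among the three measured.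

Compound 4 `Brc1ccccc1OC1CCN(c2ccc(-n3ccnc3)nn2)CC1` has not yet been measured. It differs from compound 3 in one place: bromo in place of ethyl on an aromatic carbon. Among the compounds with values here, no measured pair carries this same change, so the expectation for compound 4 rests on compound 3 alone and on the general experience that a single substituent swap of this kind at one aromatic carbon rarely moves a number far. The step from compound 3 to compound 4 is expected to be small, a 1.8-fold higher number from compound 3 to compound 4 (0.24 log units; within the scatter), within or only just beyond the scatter, with a slight weakening the more likely direction. Compound 4 is therefore estimated at 7 nM, with a range from 2 nM to 25 nM.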

Compound 4, half-maximal inhibitory concentration: 5 nM
Estimate against measurement, compound 4: 1.4-fold (0.15 log units) above; the measured number falls inside the stated range.
By their numbers in this assay, from the lowest: compounds 3 and 4 (each within the scatter of the next); then compound 2; then compound 1.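

In this assay the swap from 2-ethylphenyl to 2-bromophenyl gives a 1.3-fold higher number from compound 3 to compound 4 (0.10 log units; within the scatter) and leaves the two compounds indistinguishable on this read-out. Within the data shown here, this is the first pair that differs in one place, and it shows that, on this aromatic carbon ortho to a large group, ethyl and bromo give numbers that cannot be told apart, even though they differ in heavy atoms and element. No supporting data bear on why the two groups read alike.

On these data alone, whether this carbon accepts groups of a different kind, such as an amine, a carboxylic acid or a longer chain, remains open. As far as these compounds go, compound 1 and compound 2 each differ from compound 3 in more than one place, so the separate contribution of each of those differences also remains open.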